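The source may report more compounds than this note shows. Statements on the series, on what has been measured and on what is new or still open speak of the compounds shown alone.

Compound 1 `COc1cc(/C=C/C(=O)/C=C/c2cccs2)ccc1OCc1cn(CCOc2cc(=O)oc3ccccc23)nn1`: 71%
Compound 2 `COc1cc(/C=C/C(=O)/C=C/c2ccccc2)ccc1OCc1cn(CCOc2cc(=O)oc3ccccc23)nn1`: 56%

Among the compounds with values here, in a functional assay on HCT-116 cells (Homo sapiens) for inhibition, read by sulforhodamine B assay, with a stated time of 48 h, tested at 50 uM (a lower number here means less inhibition of growth, a higher number more inhibition of growth at the concentration tested), compound 2 gives 56%, the lower of the two numbers measured so far, and compound 1 stands higher at 71%. Compound 3 `COc1cc(/C=C/C(=O)/C=C/c2ccco2)ccc1OCc1cn(CCOc2cc(=O)oc3ccccc23)nn1` carries one change relative to compound 2: furan-2-yl in place of phenyl on a double-bonded chain carbon bound to a double-bonded chain carbon. Within the data shown here, the only measured step bearing on this is a number 15 percentage points lower from compound 1 to compound 2 (beyond the scatter), where phenyl took the place of thiophen-2-yl at the same place. The new change also removes phenyl, so a modest rise is expected, though a single step is thin evidence. The expected change is a number 9 percentage points higher from compound 2 to compound 3 (within the scatter). Compound 3 is estimated at 65%, with an expected range of 52% to 78%.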

Compound 3, percent growth inhibition at one concentration: 72%
Beside the measured number, compound 3's estimate is 7 percentage points below it; the range from low to high includes it.
By their numbers in this assay, from the lowest: compound 2; then compounds 1 and 3 (each within the scatter of the next).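

In this assay, within the data shown here, furan-2-yl in place of phenyl on a double-bonded chain carbon bound to a double-bonded chain carbon gives a number 16 percentage points higher from compound 2 to compound 3 (beyond the scatter), so thiophen-2-yl is not the only group here that stands clear of phenyl. Furan-2-yl in place of thiophen-2-yl gives a number 1 percentage points higher from compound 1 to compound 3 (within the scatter), so this assay does not separate these two five-membered rings. Nothing available accounts for the difference from phenyl. Still open, going by these compounds, is whether pyridin-2-yl would fall with phenyl or with the five-membered rings, and what an amine on the phenyl ring would do.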